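The source may hold more compounds than are shown below. What is called first, only, known or untested is meant among the compounds shown, and "the series" means these compounds.

Compound 1 `COc1ccc(N2C(=O)COc3ccc(-c4cnc(Cl)c(NS(=O)(=O)c5ccc(F)cc5)c4)cc32)cc1` and compound 2 `O=C1COc2ccc(-c3cnc(Cl)c(NS(=O)(=O)c4ccc(F)cc4)c3)cc2N1c1ccc(F)cc1` share one core, while compound 3 `COc1ccc(N2C(=O)COc3ccc(-c4cnc5ccccc5c4)cc32)cc1` and compound 4 `O=C1COc2ccc(-c3cnc4ccccc4c3)cc2N1c1ccc(F)cc1` share another; the difference between the two cores is not broken down here. The same change links each pair: fluoro in place of methoxy on an aromatic carbon in the first, and fluoro in place of methoxy on an aromatic carbon in the second, at a place described in identical words, so it is the same change. In a functional assay on A549 cells (Homo sapiens) for antiproliferative activity, read by MTT assay, with a stated time of 72 h (on this read-out lower numbers stand for stronger inhibition and higher numbers for weaker inhibition), compound 1 gives 30400 nM. Compound 2 gives 22300 nM in this assay. The step of a 1.4-fold lower number from compound 1 to compound 2 (0.13 log units; within the scatter). Compound 3 sits at the limit of > 40000 nM in this assay, at which 1 of the 3 values shown sits, and gives > 40000 nM, a limit of the assay rather than a number. Compound 4 has not yet been measured in this assay. Since the earlier step of a 1.4-fold lower number from compound 1 to compound 2 (0.13 log units; within the scatter) stayed within the scatter, the change is expected to make a step that the limit leaves unreadable from compound 3 to compound 4, which would leave compound 4 near the limit. Compound 4 is therefore expected to give about 45000 nM, with a range estimated from 20000 nM to 120000 nM, and a good chance that this assay again reports only a limit.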

Compound 4, half-maximal inhibitory concentration: > 40000 nM
Compound 4: a limit, no number; the forecaster's own chance of this, stated with the estimate: 65%; the middle value is on the limit's open side.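

Among the compounds shown here, compound 3 and compound 4 both stand at the same limit of this assay, not at numbers, so no step between them can be read: the limit of > 40000 nM in this assay, at which 2 of the 4 values shown sit. The compounds shown leave open whether fluoro in place of methoxy changes anything on the core shared by compound 3 and compound 4.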